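The source may report more compounds than this note shows. Statements on the series, on what has been measured and on what is new or still open speak of the compounds shown alone.

Working notes on the series. Among the measured compounds shown here, compound 1 `CCN(CC)c1cc2[nH]c(C3CCCCC3)nc2cc1NC(=O)c1ccc(N(C)C)cc1` is the first member; in an ADME assay on Vero cells (Chlorocebus sabaeus) for cytotoxicity, read by resazurin assay, with a stated time of 3 days (a lower number here means a stronger inhibitor, a higher number a weaker inhibitor), compound 1 gives "not determined" (no result reported), so it contributes no number to the picture. Compound 2 `CCCOCC(=O)Nc1cc2nc(C3CCCCC3)[nH]c2cc1N(CC)CC` is the second member. In this assay compound 2 gives > 100 ug/mL, which is a limit of the assay and not a number. Compound 2 therefore sits at the limit of > 100 ug/mL in this assay, at which 1 of the 2 values shown sits, and no single value for any member of the series is yet in hand. Compound 3 `C=Cc1cccc(C(=O)Nc2cc3nc(C4CCCCC4)[nH]c3cc2N(CC)CC)c1` is the next member to be read. It differs from compound 2 by 3-vinylphenyl in place of propoxymethyl on a carbonyl carbon. For the measured compounds named here, no step between two measured compounds is available, so the size of this change in this assay cannot be taken from the series itself. The expectation is that compound 3 shows no shift beyond the usual scatter, with a fair chance that it again returns only a limit, and some room left on the lower side for a moderately stronger cytotoxic reading. Compound 3 is estimated at 90 ug/mL, within 35 ug/mL to 250 ug/mL. The step from compound 2 to compound 3 is accordingly expected to be an at least 1.1-fold lower number from compound 2 to compound 3 (0.04 log units; that floor lies within the scatter).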

Compound 3, half-maximal inhibitory concentration: > 100 ug/mL
Compound 3: no number, only a limit; the forecaster's own chance of this, stated with the estimate: 55%; middle value at least 1.1-fold (0.04 log units) away from the limit.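

Among the compounds shown here, no step from compound 2 to compound 3 can be read in this assay, as both return only a limit of the assay and not a number: the limit of > 100 ug/mL in this assay, at which 2 of the 3 values shown sit. The compounds shown leave open how large the change from propoxymethyl to 3-vinylphenyl is in this assay, and whether any member of the series gives a single value there.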